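The source may report more compounds than this note shows. Statements on the series, on what has been measured and on what is new or still open speak of the compounds shown alone.

Values in a functional assay on VCaP cells (Homo sapiens) for antiproliferative activity, read by CCK-8 assay, with a stated time of 6 days; on this read-out higher numbers stand for weaker inhibition and lower numbers for stronger inhibition:
- compound 1 `CCN(c1ccc(C#N)c(Cl)c1)c1cc(-c2cccs2)ccc1C`: "not determined" (no result reported)
- compound 2 `CCN(c1ccc(C#N)c(Cl)c1)c1cc(C2=CCCCC2)ccc1C`: 20000 nM
- compound 3 `CCN(c1ccc(C#N)c(Cl)c1)c1cc(-c2c[nH]nc2C)ccc1C`: 3190 nM

Compound 3 holds the lower of the two numbers available in this assay, and compound 1 contributes no number. The next structure is compound 4 `CCN(c1ccc(C#N)c(Cl)c1)c1cc(-n2ccnc2)ccc1C`, which carries 1H-imidazol-1-yl in place of 3-methyl-1H-pyrazol-4-yl on an aromatic carbon. Both groups are five-membered aromatic rings, and the place of the change is the same one that varies across the measured compounds.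

Among the compounds with values here, only one measured step bears on this change: a 6.3-fold lower number from compound 2 to compound 3 (0.80 log units; beyond the scatter). It is modest, and it replaces cyclohex-1-en-1-yl rather than a five-membered aromatic ring, so it gives a rough upper guide to size and no firm direction. A smaller swap between two such rings should therefore move the number less, with a slight lean upward. The expected change is a 1.6-fold higher number from compound 3 to compound 4 (0.20 log units; within the scatter), which is not expected to exceed the scatter. For compound 4 the estimated value in this assay is 5000 nM, with an expected range of 1500 nM to 16000 nM.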

Compound 4, half-maximal inhibitory concentration: > 30000 nM
Compound 4 ended at the assay's limit (the forecaster's own chance of this, stated with the estimate: 12%); middle value at least 6.0-fold (0.77 log units) away from the limit.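

In this assay compound 4 gives > 30000 nM, a limit of the assay and not a number: the limit of > 30000 nM in this assay, at which 1 of the 4 values shown sits.

Two five-membered aromatic rings with 2 hetero atoms are therefore not interchangeable on this aromatic carbon, para to the methyl group: the change gives an at least 9.4-fold higher number from compound 3 to compound 4 (0.97 log units; beyond the scatter). Against the non-aromatic group, the change gives an at least 1.5-fold higher number from compound 2 to compound 4 (0.17 log units; that floor lies within the scatter), so no order can be stated for that pair, and among the compounds with a reading only compound 3 stands clear of the others.

The step from 3-methyl-1H-pyrazol-4-yl to 1H-imidazol-1-yl changes the ring, the methyl group and the hydrogen-bond donor count together, and the compounds shown do not separate these. Also open, on these data alone, is how 1H-pyrazol-4-yl without the methyl group, or a small amine on this carbon, would read against compound 3.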